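The compounds below may be only part of what the source reports. "The series", "measured", "known", "first", "only" and "open" are said of these compounds alone.

In a functional assay on HEL cells (Homo sapiens) (on this read-out lower numbers stand for higher toxicity in this test and higher numbers for lower toxicity in this test), compound 1, whose structure is `CCCCCCCCC#Cc1cc2cn(COCCO)c(=O)nc2o1`, gives 42000 nM, the lowest of the two numbers this small set has produced. The nearest number belongs to compound 3, with the structure `CO[C@H]1[C@H](O)[C@@H](O)[C@@H](O)O[C@@H]1C(=O)O`, which in this assay gives 130000 nM; the gap between compound 1 and compound 3 lies beyond the usual scatter of repeated measurements. Compound 2, with the structure `CCCCCCCCCCc1cc2cn(COCCO)c(=O)nc2o1`, in this assay gives > 200000 nM, which is a limit of the test and not a number; this is the limit of > 200000 nM in this assay, at which 1 of the 3 values shown sits, and so compound 2 supplies no number to compare. Within the data shown here, no two of these measured compounds differ from one another in a single place, so there is no measured step to lean on.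

The account now turns to compound 4, whose structure is `CCCCC#Cc1cc2cn(COCCO)c(=O)nc2o1`, and to its step from compound 1. The change is hydrogen in place of butyl on a saturated chain carbon, four bonds along the chain from a triple-bonded carbon. The shared core is left untouched; only the chain is shortened. Among the measured compounds shown here, with no measured step of this kind to guide it, the expectation rests on the change alone and is held loosely. The step is expected to be a 2.1-fold higher number from compound 1 to compound 4 (0.33 log units; beyond the scatter), a modest move toward a higher number in this assay. For compound 4 the estimated value is 90000 nM, expected to fall between 35000 nM and 200000 nM.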

Compound 4, half-maximal cytotoxic concentration: > 50000 nM
Compound 4: a limit, no number (the forecaster's own chance of this, stated with the estimate: 25%); the middle value does not contradict the limit.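

In this assay compound 4 gives > 50000 nM, which is a limit of the assay and not a number. Hydrogen in place of butyl on a saturated chain carbon, four bonds along the chain from a triple-bonded carbon, therefore reads as an at least 1.1-fold higher number from compound 1 to compound 4 (0.07 log units; that floor lies within the scatter), so the change can be given only as a floor, and the true size of the step may be larger than that floor. This is the first step in the set between two compounds that differ in one place, and it ties the shortened chain to a lower bound on the read-out instead of a measured size, as its reading rests on a limit: the limit of > 50000 nM in this assay, at which 1 of the 4 values shown sits.

The compounds shown leave open whether the full step from butyl to hydrogen at this place lies beyond the usual scatter, and how large it is, since only the floor can be read. They also leave open how the number in this assay would respond to a longer chain at this place, or to an amine or a carboxylic acid carried on the chain in place of the butyl.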